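This account rests on a few compounds, and the source may have more. Where it says the series, first, only, none or still open, it means among the compounds named here.

Working notes on the series built on the core of compound 1 `N#Cc1c(N2CCC(c3ccccc3)CC2)ccn(CC2CCC2)c1=O`, where the three measured compounds differ only in the group on the saturated chain carbon bound to an aromatic nitrogen. In a functional assay on CHO cells for positive allosteric modulation of metabotropic glutamate receptor 2 (Homo sapiens), with a stated time of 30 min (a higher number here means that more compound is needed for the effect, a lower number that less compound is needed), compound 1 gives 55 nM. Compound 2 `N#Cc1c(N2CCC(c3ccccc3)CC2)ccn(CC2CC2)c1=O` gives 151 nM in this assay, and compound 3 `N#Cc1c(N2CCC(c3ccccc3)CC2)ccn(CCC2CC2)c1=O` gives 178 nM. The steps run a 2.7-fold higher number from compound 1 to compound 2 (0.44 log units; beyond the scatter) and a 3.2-fold higher number from compound 1 to compound 3 (0.51 log units; beyond the scatter), while the step of a 1.2-fold higher number from compound 2 to compound 3 (0.07 log units; within the scatter). Compound 2 thus stands second highest of the three numbers, near compound 3 and apart from compound 1.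

Compound 4 `N#Cc1c(N2CCC(c3ccc(F)cc3F)CC2)ccn(CC2CC2)c1=O` differs from compound 2 by 2,4-difluorophenyl in place of phenyl on a saturated ring carbon. Going by the values given here, none of the measured steps touches this ring; all three concern the chain group, so no measured step bears on the change. With no guide in the data, no step beyond the scatter is expected, a 1.0-fold lower number from compound 2 to compound 4 (0.00 log units; within the scatter). Compound 4 is therefore estimated at 150 nM, within 50 nM to 450 nM.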

Compound 4, half-maximal effective concentration: 68 nM
Compound 4: the middle estimate sits 2.2-fold (0.34 log units) above what was measured, and the stated range covers the measured number.
By their numbers in this assay, from the lowest: compounds 1 and 4 (each within the scatter of the next); then compounds 2 and 3 (each within the scatter of the next).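

Going by these compounds alone, the phenyl on the saturated ring carbon is a second position that moves the number in this assay, where the earlier compounds varied only the chain group: 2,4-difluorophenyl in place of phenyl gives a 2.2-fold lower number from compound 2 to compound 4 (0.35 log units; beyond the scatter). No measurement at hand accounts for this step. As far as these compounds go, whether 2-fluorophenyl or 4-fluorophenyl alone would give the same step remains open, as does the effect of a chlorophenyl or a pyridine ring here. Also open, from the compounds shown here alone, is whether the 2,4-difluorophenyl change adds to the cyclobutyl chain group of compound 1.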